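This account rests on a few compounds, and the source may have more. Where it says the series, first, only, none or still open, it means among the compounds named here.

Of the compounds shown here, three sharing one core have been tested so far in a functional assay on HCC827 cells (Homo sapiens) for antiproliferative activity, read by sulforhodamine B assay, with a stated time of 72 h; a lower number here means a stronger inhibitor, a higher number a weaker inhibitor. Compound 1 `CN(CCNCc1cn(-c2cccc(Cl)c2)nn1)CCNc1ccnc2cc(Cl)ccc12` gives 9400 nM in this assay. Compound 2 `CN(CCNCc1cn(C(C)(C)C)nn1)CCNc1ccnc2cc(Cl)ccc12` gives 56000 nM. Compound 3 `CN(CCNCc1cn(-c2ccnc3cc(Cl)ccc23)nn1)CCNc1ccnc2cc(Cl)ccc12` gives 18000 nM, which places it second highest of the three numbers: compound 1 sits nearest, the step being a 1.9-fold higher number from compound 1 to compound 3 (0.28 log units; within the scatter), while compound 2 is furthest, the step being a 3.1-fold lower number from compound 2 to compound 3 (0.49 log units; beyond the scatter).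

Compound 4 `CN(CCNCc1cn(CCCn2nn[nH]c2=O)nn1)CCNc1ccnc2cc(Cl)ccc12` differs from compound 3 in one place: a group of 9 heavy atoms (4 carbon, 4 nitrogen, 1 oxygen; one five-membered aromatic ring with 4 hetero atoms) in place of a group of 11 heavy atoms (9 carbon, 1 nitrogen, 1 chlorine; one six-membered aromatic ring of carbon only, one six-membered aromatic ring with 1 hetero atom), on an aromatic nitrogen. The measured steps that bear on this change are those in which the group on that same aromatic nitrogen was exchanged. Swapping one aromatic group for another gave a 1.9-fold higher number from compound 1 to compound 3 (0.28 log units; within the scatter), within the scatter. Replacing an aromatic group by tert-butyl, a non-aromatic group, gave a 6.0-fold higher number from compound 1 to compound 2 (0.78 log units; beyond the scatter), and the reverse exchange gave a 3.1-fold lower number from compound 2 to compound 3 (0.49 log units; beyond the scatter). Going by the values given here, the incoming group in compound 4 is neither a six-membered aromatic ring nor tert-butyl, so no measured step matches it directly; the nearest guide is that leaving the aromatic bicycle for a different kind of group raised the number. A modest rise beyond the scatter is therefore expected, a 2.2-fold higher number from compound 3 to compound 4 (0.35 log units; beyond the scatter). Compound 4 is estimated to give 40000 nM in this assay, within a range from 12000 nM to 130000 nM.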

Compound 4, half-maximal inhibitory concentration: > 200000 nM
Compound 4: a limit, no number; the forecaster's own chance of this, stated with the estimate: 15%; middle value at least 5.0-fold (0.69 log units) away from the limit.
By their numbers in this assay, from the lowest: compounds 1 and 3 (each within the scatter of the next); then compound 2. At a limit, above all of these: compound 4.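

Compound 4 sits at a limit of this assay, which is not a number: the limit of > 200000 nM in this assay, at which 1 of the 4 values shown sits.

Each step to it is therefore a minimum, and all three lie beyond the scatter: an at least 11-fold higher number from compound 3 to compound 4 (1.04 log units; beyond the scatter), an at least 21-fold higher number from compound 1 to compound 4 (1.32 log units; beyond the scatter) and an at least 3.5-fold higher number from compound 2 to compound 4 (0.55 log units; beyond the scatter). The earlier compounds shown here showed only that 3-chlorophenyl, tert-butyl and 7-chloroquinolin-4-yl on this aromatic nitrogen all give measured numbers, with steps among them that are modest or within the scatter; compound 4 shows that the group here can also carry the read-out past all of those numbers, so this position is not indifferent to what it bears.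

The entering group brings a chain, a five-membered aromatic ring with 4 hetero atoms and a double bond outside that ring all at once, so the compounds shown cannot say which of these parts goes with the result. From the compounds shown here alone, a plain alkyl chain without the ring, or a chain ending in an amine or a carboxylic acid, would help to separate them, and how far compound 4 lies beyond its limit stays unknown.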